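Benzothiophene in place of fluoropyridine: the expected clearance step

This account rests on a few compounds, and the source may have more. Where it says the series, first, only, none or still open, it means among the compounds named here.

Compound 2 `Nc1ccc(S(=O)(=O)N2CCN(c3ncc(C(O)(C(F)(F)F)C(F)(F)F)cc3-c3cncc(F)c3)CC2)cn1` gives 19 mL.min-1.g-1 in an ADME assay (liver) for metabolic stability, with Liver microsome (Rattus norvegicus) as the target, using microsomes and NADPH, with a stated time of 30 min, tested at 1 uM (a higher number here means faster removal of the compound, a lower number slower removal), the lowest of the two numbers recorded; its nearest neighbour is compound 1 `Cc1csc(-c2cc(C(O)(C(F)(F)F)C(F)(F)F)cnc2N2CCN(S(=O)(=O)c3ccc(N)nc3)CC2)c1`, which gives 399 mL.min-1.g-1. Among the compounds with values here, the one step known, a 21-fold lower number from compound 1 to compound 2 (1.32 log units; beyond the scatter), is large and beyond the scatter. Compound 3 `Nc1ccc(S(=O)(=O)N2CCN(c3ncc(C(O)(C(F)(F)F)C(F)(F)F)cc3-c3cc4ccccc4s3)CC2)cn1` differs from compound 2 by 1-benzothiophen-2-yl in place of 5-fluoropyridin-3-yl on an aromatic carbon, on an aromatic carbon of a six-membered aromatic ring with 1 nitrogen. The move from compound 1 to compound 2 replaced a sulfur-containing five-membered ring by 5-fluoropyridin-3-yl and brought the large drop; compound 3 reverses that, bringing in a larger 1-benzothiophen-2-yl group, so a large rise in this assay is expected for compound 3, of about a 16-fold higher number from compound 2 to compound 3 (1.20 log units; beyond the scatter). Compound 3 is therefore estimated at 300 mL.min-1.g-1, with a likely range from 80 mL.min-1.g-1 to 1000 mL.min-1.g-1.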

Compound 3, intrinsic clearance in microsomes: 315 mL.min-1.g-1
Estimate against measurement, compound 3: 1.1-fold (0.02 log units) below; the range from low to high includes it.
By their numbers in this assay, from the lowest: compound 2; then compounds 3 and 1 (each within the scatter of the next).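

In this assay, the aromatic carbon two atoms from the ring nitrogen now carries three different groups, and a 17-fold higher number from compound 2 to compound 3 (1.22 log units; beyond the scatter) shows that the low number of compound 2 does not extend to the larger 1-benzothiophen-2-yl. The two sulfur-containing groups are not separated, with a 1.3-fold lower number from compound 1 to compound 3 (0.10 log units; within the scatter) despite the added six-membered aromatic ring, so among these three compounds only the 5-fluoropyridin-3-yl group stands apart, at the low end. No measurement shown here offers an explanation for this split.

The compounds leave open whether the low number goes with the ring nitrogen, the fluorine or both, which a plain phenyl or an unsubstituted pyridin-3-yl at this place would help to separate. As far as these compounds go, whether the split would persist with a carboxylic acid in place of the 2,2,2-trifluoro-1-hydroxy-1-(trifluoromethyl)ethyl group also remains open.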